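The source may hold more compounds than are shown below. What is called first, only, known or untested is meant among the compounds shown, and "the series" means these compounds.

Compound 1 `CCOC(=O)C(C)C(O)(c1ccc(OC)c(OC)c1OC)c1cccc2ccccc12` gives 4000 nM in a functional assay on A549 cells (Homo sapiens) for inhibition, read by sulforhodamine B assay, with a stated time of 48 h; a lower number here means a stronger inhibitor, a higher number a weaker inhibitor. Compound 2 `COc1ccc(C(O)(C/C=C\c2ccccc2)c2cccc3ccccc23)c(OC)c1OC` gives 17600 nM in this assay. Compound 3 `COc1ccc(/C(=N/O)c2cccc3ccccc23)c(OC)c1OC` gives 13100 nM in this assay.

Compound 2 stands at the top of the three numbers. Going by the values given here, the gap to compound 3 falls within the usual scatter, so the two are not separated; the only step beyond the scatter is a 4.4-fold higher number from compound 1 to compound 2 (0.64 log units; beyond the scatter), which runs from the ester-bearing substituent of compound 1 to the 3-phenylprop-2-en-1-yl of compound 2.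

The next compound, compound 4 `COc1ccc(C(O)(Cc2ccccc2)c2cccc3ccccc23)c(OC)c1OC`, differs from compound 2 in one place: phenyl in place of 2-phenylethenyl on a saturated chain carbon, two bonds along the chain from two aromatic carbons and an oxygen on a saturated carbon.

Among the compounds with values here, only one measured step touches this position, a 4.4-fold higher number from compound 1 to compound 2 (0.64 log units; beyond the scatter), and it swaps a quite different group, so it bears on the present change only loosely. The values of compound 2 and compound 3 show that a change of the whole substituent at the carbinol carbon can leave the number within the scatter. Within the data shown here, no measured pair isolates the loss of the double bond and the shortening of the chain. The expectation is therefore a step of a 1.5-fold lower number from compound 2 to compound 4 (0.17 log units; within the scatter), not beyond the scatter in either direction. Compound 4 is estimated at 12000 nM, with a range of 5000 nM to 30000 nM.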

Compound 4, half-maximal inhibitory concentration: > 20000 nM
Compound 4 ended at the assay's limit (the forecaster's own chance of this, stated with the estimate: 5%); middle value at least 1.6-fold (0.22 log units) away from the limit.
By their numbers in this assay, from the lowest: compound 1; then compounds 3 and 2 (each within the scatter of the next). At a limit, above all of these: compound 4.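

Compound 4 reads as a limit of the assay in this assay, not as a number: the limit of > 20000 nM in this assay, at which 1 of the 4 values shown sits. Benzyl in place of 3-phenylprop-2-en-1-yl, which removes the double bond outside the aromatic rings, gives an at least 1.1-fold higher number from compound 2 to compound 4 (0.05 log units; that floor lies within the scatter), so this floor does not separate the two compounds, and the change brings no lower number. Benzyl in place of 1-(ethoxycarbonyl)ethyl gives an at least 5.0-fold higher number from compound 1 to compound 4 (0.69 log units; beyond the scatter), which adds a second substituent ending in a phenyl ring to the one already beyond the scatter from the ester-bearing group on the saturated chain carbon bound to two aromatic carbons and an oxygen.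

The compounds shown leave open how far the number of compound 4 lies past its limit, and so whether the double bond and chain length matter at all at this position. They also leave open which part of 1-(ethoxycarbonyl)ethyl carries the difference, and whether a carboxylic acid in place of the ethyl ester, or an amine such as 2-aminoethyl on the same carbon, would hold or lower the number.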